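Dropping a Chloro Group in a Series Without Readable Potency

The source may hold more compounds than are shown below. What is called first, only, known or untested is meant among the compounds shown, and "the series" means these compounds.

Compound 1 `O=c1c(SC(=S)N2CCCC2)coc2ccc(Cl)cc12` and compound 4 `O=c1c(SC(=S)N2CCCC2)coc2ccccc12` share one core, while compound 2 `O=c1cc(CSC(=S)N2CCCCC2)oc2cc(Cl)ccc12` and compound 3 `O=c1cc(CSC(=S)N2CCCCC2)oc2ccccc12` share another; the difference between the two cores is not broken down here. In a functional assay on MCF7 cells (Homo sapiens) for antiproliferative activity, read by MTT assay, with a stated time of 72 h (on this read-out higher numbers stand for weaker inhibition and lower numbers for stronger inhibition), compound 1 reaches only a limit of the assay, > 25000 nM. Compound 2 likewise gives only a limit, > 25000 nM. Compound 3 also gives only a limit, > 25000 nM. The change from compound 2 to compound 3 is hydrogen in place of chloro on an aromatic carbon, and the step that the two limits leave unreadable from compound 2 to compound 3 sits between two limits, so its size cannot be read. The same change is made from compound 1 to compound 4: hydrogen in place of chloro on an aromatic carbon. For the measured compounds named here, the only evidence on the measured step is the limit of > 25000 nM in this assay, at which 3 of the 3 values shown sit, so no effect of removing the chloro group can be seen in this set. Compound 4 is therefore expected to give 30000 nM, most likely between 8000 nM and 120000 nM, which rests on the limit of compound 1 and on (the limit of > 25000 nM in this assay, at which 3 of the 3 values shown sit). The expected step that the limit leaves unreadable from compound 1 to compound 4 is estimated as essentially flat, with a high chance that only a limit is reported again.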

Compound 4, half-maximal inhibitory concentration: 12200 nM
Compound 4: middle estimate off by 2.5-fold (0.39 log units), on the high side; the measured number falls inside the stated range.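

In this assay, hydrogen in place of chloro on the core of compound 1 gives an at least 2.0-fold lower number from compound 1 to compound 4 (0.31 log units; beyond the scatter), which is beyond the usual scatter, and the size printed is only a minimum. On the other core, the same change from compound 2 to compound 3 sits between two limits, so that step cannot be read, and the data neither support nor contradict the idea that the effect carries from one core to the other. The one readable step therefore stands alone, on a single core, and most of the series offers no number to set beside it: the limit of > 25000 nM in this assay, at which 3 of the 4 values shown sit.

From the compounds shown here alone, whether another group at the same place, such as fluoro, methoxy or an amine, would give a lower number than hydrogen remains open. Also open, going by these compounds, is how the chloro change would read on the core of compound 2 if compounds there gave numbers rather than limits.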